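A few compounds are considered here, and "the series" means these few. Any claim that something is new, unique, unknown or untested is made for them only; others in the source may bear on it.

Measured so far in an ADME assay on microsomes from liver (Homo sapiens) for metabolic stability, read by LC-MS, with a stated time of 30 min, tested at 1 uM; on this read-out lower numbers stand for slow clearance and higher numbers for fast clearance:
compound 1 `C[C@@H](c1ccc2ncccc2c1)c1nnc2ccc(-c3cccc(C#N)c3)nn12`: 17.9 mL.min-1.g-1
compound 2 `COc1ccc(-c2ccc3nnc([C@@H](C)c4ccc5ncccc5c4)n3n2)cc1F`: 281 mL.min-1.g-1
compound 3 `COc1ccc(-c2ccc3nnc([C@@H](C)c4ccc5ncccc5c4)n3n2)cc1C`: 304 mL.min-1.g-1

Compound 3 cannot be separated from compound 2, as the record shows a 1.1-fold higher number from compound 2 to compound 3 (0.03 log units; within the scatter). Compound 1 lies far from it, with a 17-fold higher number from compound 1 to compound 3 (1.23 log units; beyond the scatter).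

Compound 4 `Cc1cccc(-c2ccc3nnc([C@@H](C)c4ccc5ncccc5c4)n3n2)c1` has hydrogen in place of methoxy on an aromatic carbon, so 4-methoxy-3-methylphenyl becomes 3-methylphenyl.

Within the data shown here, no measured step removes this methoxy on its own, so the evidence is indirect. With methoxy kept, the exchange of fluoro for methyl gave a 1.1-fold higher number from compound 2 to compound 3 (0.03 log units; within the scatter). Two large steps lead away from the nitrile-bearing compound 1: a 16-fold higher number from compound 1 to compound 2 (1.20 log units; beyond the scatter) and a 17-fold higher number from compound 1 to compound 3 (1.23 log units; beyond the scatter). Both of these steps bring in methoxy, but they also remove the nitrile, and the data do not separate the two changes. Compound 4 has neither group, so its value is expected to fall between those of compound 1 and compound 3, closer to the latter. The expected step is a 2.3-fold lower number from compound 3 to compound 4 (0.37 log units; beyond the scatter), a modest fall in this assay, and a result within the scatter remains possible. For compound 4 the estimate is 130 mL.min-1.g-1, with an expected range of 45 mL.min-1.g-1 to 320 mL.min-1.g-1.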

Compound 4, intrinsic clearance in microsomes: 81.8 mL.min-1.g-1
Estimate against measurement, compound 4: 1.6-fold (0.20 log units) above; low and high end bracket the measured number.
By their numbers in this assay, from the lowest: compound 1; then compound 4; then compounds 2 and 3 (each within the scatter of the next).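

In this assay, among these compounds, the single exchange of hydrogen for methoxy gives a 3.7-fold lower number from compound 3 to compound 4 (0.57 log units; beyond the scatter), the first reading of this position with nothing else changed: the 4-methoxy group is part of the high clearance numbers of this pair, but it is not the whole of them. The wider exchange gives a similar picture, with a 3.4-fold lower number from compound 2 to compound 4 (0.54 log units; beyond the scatter), while a 4.6-fold higher number from compound 1 to compound 4 (0.66 log units; beyond the scatter) shows that methyl in place of cyano raises the number with no methoxy involved, so the large steps away from compound 1 now split into two readable parts, one at the nitrile and one at the methoxy. Nothing at hand accounts for either part.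

Going by these compounds, it remains open whether the methoxy step holds on other rings, such as a 3-cyanophenyl ring carrying a methoxy or a 3-fluorophenyl ring without one, since the two parts have been read on only these few compounds. Also open, on these data alone, is how an amine, a carboxylic acid or a longer alkoxy chain would read at this same place, para to a large group and ortho to a methyl group.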